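Azo series: tolerance on Vero cells, aryl swap

A few compounds are considered here, and "the series" means these few. Any claim that something is new, unique, unknown or untested is made for them only; others in the source may bear on it.

Measured so far:
- compound 1 `Fc1ccc(F)c(/N=N/c2ccc(NC[C@@H]3CCCN4CCCC[C@H]34)c3c2CCCC3)c1`: 80000 nM
- compound 2 `CN(C)CCCN(/N=N/c1ccccc1)c1cccc(C(F)(F)F)c1`: 20000 nM

In an ADME assay on Vero cells (Chlorocebus sabaeus) for cytotoxicity, read by crystal violet staining (a higher number here means that more compound is tolerated, a lower number that less compound is tolerated), compound 1 gives 80000 nM, the higher of the two values; compound 2 gives 20000 nM, a gap beyond the scatter. Compound 3 `FC(F)(F)c1cccc(/N=N/c2ccc(NC[C@@H]3CCCN4CCCC[C@H]34)c3c2CCCC3)c1` keeps the core of compound 1 and changes only the aryl ring: 3-(trifluoromethyl)phenyl in place of 2,5-difluorophenyl on a double-bonded nitrogen. Going by the values given here, no measured pair isolates this change; compound 2 carries the same 3-(trifluoromethyl)phenyl on a different scaffold, so its value is no guide. A small downward step, possibly within the scatter, is expected for a 1.6-fold lower number from compound 1 to compound 3 (0.20 log units; within the scatter). Compound 3 is estimated at 50000 nM, range 20000 nM to 120000 nM.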

Compound 3, half-maximal cytotoxic concentration: 50000 nM
The estimate for compound 3 equals the measured number at the digits printed; the measured number falls inside the stated range.
By their numbers in this assay, from the lowest: compound 2; then compounds 3 and 1 (each within the scatter of the next).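

In this assay the aryl ring on a double-bonded nitrogen gets its first matched comparison: 3-(trifluoromethyl)phenyl in place of 2,5-difluorophenyl gives a 1.6-fold lower number from compound 1 to compound 3 (0.20 log units; within the scatter) on the shared core. At this position the two rings cannot be told apart in tolerance, despite their different fluorine substitution. No supporting data bear on the reason for this outcome. Open, from the compounds shown here alone, is whether an amine or a carboxylic acid on this aryl ring would stay equally tolerated. Going by these compounds, the shared core's side chain also remains untested here against a longer chain.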